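A few compounds are considered here, and "the series" means these few. Any claim that something is new, unique, unknown or untested is made for them only; others in the source may bear on it.

Three small thiourea compounds sharing a common core were tested for their effect on living human cells. Compound 1 `O=C(NC(=S)Nc1nc[nH]n1)c1ccccc1`, compound 2 `Fc1ccc(NC(=S)Nc2nc[nH]n2)cc1` and compound 3 `S=C(Nc1nc[nH]n1)Nc1ccccc1Br` were each examined in an ADME assay on MT4 cells (Homo sapiens) for cytotoxicity, read by MTT assay, with a stated time of 96 h; on this read-out higher numbers stand for lower toxicity in this test and lower numbers for higher toxicity in this test. In this assay compound 1 gives > 100000 nM, which is a limit of the measurement rather than a number. Compound 2 gives > 100000 nM in this assay, again a limit and not a number. Compound 3 gives > 100000 nM in this assay, once more a limit. All three values sit at the limit of > 100000 nM in this assay, at which 3 of the 3 values shown sit, so compound 2 stands level with the other two on the numbers shown, and no order can be read among them.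

Compound 4 `S=C(Nc1ccc(Cl)cc1)Nc1nc[nH]n1` has not yet been measured. It differs from compound 2 by chloro in place of fluoro on an aromatic carbon. Going by the values given here, no step between measured compounds is available, so the expectation for compound 4 rests on the three limits alone. With every measured value at the same limit, the step from compound 2 to compound 4 is expected to be a number no higher from compound 2 to compound 4 (the limit leaves the size open), that is, none beyond the usual scatter. Compound 4 is therefore expected to give about 100000 nM in this assay, within a range from 50000 nM to 200000 nM, and most likely to be reported again as a limit.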

Compound 4, half-maximal cytotoxic concentration: 47000 nM
The estimate for compound 4 lay 2.1-fold (0.33 log units) above the measured number; the measured number lies below the stated range.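

In this assay, putting chloro in place of fluoro on an aromatic carbon, para to a group of 9 heavy atoms, gives an at least 2.1-fold lower number from compound 2 to compound 4 (0.32 log units; beyond the scatter), and the direction of this step points to higher toxicity in this test. The earlier compounds shown here could not show that this position responds at all, since they offered no number to compare; now a swap of a single heavy atom, which adds no ring and no net charge, is seen to be enough to move the read-out beyond the usual scatter. The step has a known minimum but no known full size because one of its two ends is a limit of the assay and not a number: the limit of > 100000 nM in this assay, at which 3 of the 4 values shown sit.

Left open is what other groups at this same place, such as iodo, methyl or an amine, would do to the number in this assay. Also open, going by these compounds, is whether chloro in place of fluoro would shift the read-out in the same direction at other places on this six-membered ring, or on a compound with a different substituent elsewhere on the shared core.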